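The compounds below may be only part of what the source reports. "The series", "measured", "known", "first", "only" and "open" are said of these compounds alone.

Working notes on the series.

Compound 1 `CCCCCn1c(N)nc2c(C)cccc21` is the reference point. In an assay on HEK293 cells for agonist activity at Toll-like receptor 8 (Homo sapiens), read by reporter gene assay (on this read-out higher numbers stand for an effect only at larger amounts of compound and lower numbers for an effect already at smaller amounts), compound 1 gives 1130 nM. Going by the values given here, the only other measured member is compound 2 `CCCCCn1c(N)nc2ccc(C)cc21`, which in this assay gives 7210 nM. Of these two numbers compound 1 has the lower one; the gap between compound 1 and compound 2 lies beyond the usual scatter of repeated measurements, so compound 1 is the more active of the pair on this read-out. Among the compounds with values here, no pair of compounds that differ in one place has been measured so far, so no single-change step is known.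

The next compound is compound 3 `CCCCCn1c(N)nc2c(Br)cccc21`. Relative to compound 1 the change is bromo in place of methyl on an aromatic carbon. For a swap of one heavy atom for another at the same place, with no change in ring count, donors, acceptors or charge, the expectation in this assay is a step of modest size, if any, and its direction cannot be read from the two numbers in hand. For compound 3 the estimated value in this assay is 900 nM, with a range from 300 nM to 2700 nM. This expectation amounts to a step of a 1.3-fold lower number from compound 1 to compound 3 (0.10 log units; within the scatter) that would be expected to remain within the usual scatter.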

Compound 3, half-maximal effective concentration: "not active" (no number reported)
The entry for compound 3 holds no number; there is nothing to compare the estimate with.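

In this assay, going by these compounds alone, the entry for compound 3 reads "not active" without a number, so no step from compound 1 to compound 3 can be read. Nothing shown bears on this result. The compounds shown leave open how other groups at this place on the core of compound 1 would read out.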